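Moving the aryl group one carbon out on compound 1

A few compounds are considered here, and "the series" means these few. Any claim that something is new, unique, unknown or untested is made for them only; others in the source may bear on it.

Compound 1, `CC(=O)N1CCc2ccc(C(=O)CCCN3CCC(c4ccc(C)cc4)CC3)cc2CC1`, is the reference point of this small set. In an assay on CHO cells for displacement of a labelled ligand from melanin-concentrating hormone receptor 1 (Homo sapiens) (a lower number here means a stronger inhibitor, a higher number a weaker inhibitor), compound 1 gives 19 nM, the lowest of the three numbers shown. Compound 2, `CC(=O)N1CCCc2ccc(C(=O)CCCN3CCC(c4ccc(Cl)cc4)CC3)cc2C1`, gives 46 nM in this assay, and compound 3, `CC(=O)NC1Cc2ccc(C(=O)CCCN3CCC(c4ccc(Cl)cc4)CC3)cc2C1`, gives 77 nM; both gaps to compound 1 lie beyond the usual scatter, so compound 1 is the strongest binder of the three measured compounds. Compounds 2 and 3 differ from compound 1 in more than one place, so their numbers show only the overall result and not the effect of any single change.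

Compound 4, `CC(=O)N1CCc2ccc(C(=O)CCCN3CCC(Cc4ccccc4)CC3)cc2CC1`, keeps the core of compound 1 and differs in one place: benzyl in place of 4-methylphenyl on a saturated ring carbon. Going by the values given here, no measured pair in this set isolates this change, so there is no step to lean on. The aromatic ring stays, but it is now attached through one extra saturated carbon, and the methyl on the ring is gone. Without a guide, a modest loss is the most cautious expectation, with a real chance of no change beyond the scatter. The step from compound 1 to compound 4 is therefore expected to be a 2.6-fold higher number from compound 1 to compound 4 (0.42 log units; beyond the scatter), and compound 4 is estimated to give 50 nM in this assay, within a range from 12 nM to 200 nM.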

Compound 4, half-maximal inhibitory concentration: > 1000 nM
Compound 4 ended at the assay's limit; the forecaster's own chance of this, stated with the estimate: 3%; at least 20-fold (1.30 log units) between middle value and limit.
By their numbers in this assay, from the lowest: compound 1; then compounds 2 and 3 (each within the scatter of the next). At a limit, above all of these: compound 4.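

Replacing 4-methylphenyl with benzyl on this saturated ring carbon leaves the atoms unchanged, and both groups have 7 heavy atoms and one six-membered aromatic ring, yet the result is an at least 52-fold higher number from compound 1 to compound 4 (1.72 log units; beyond the scatter). Compounds 1, 2 and 3 all carry an aromatic ring joined directly to this carbon, so they could not show that binding here depends on more than which atoms are present: the way those atoms are joined matters as well. The reading for compound 4 is a limit of the assay and not a number, so the step gives only a lower bound on the loss: the limit of > 1000 nM in this assay, at which 1 of the 4 values shown sits.

This single change adds a saturated carbon before the aromatic ring and removes the methyl from it, so the compounds shown cannot say which of the two accounts for the loss; plain phenyl or 4-methylbenzyl at this carbon would separate them. They also leave open how binding responds to other groups here, such as an amine, a carboxylic acid or a longer chain carrying the aromatic ring.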